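Will a triazolyl ring keep the half-life long?

This account rests on a few compounds, and the source may have more. Where it says the series, first, only, none or still open, it means among the compounds named here.

In a physicochemical assay for metabolic stability, read by HPLC and mass spectrometry, in phosphate buffer, at 37 degrees C, at pH 7.4 (on this read-out higher numbers stand for a longer-lived compound and lower numbers for a shorter-lived compound), compound 1 `CN(C[C@@H]1[C@H](NC(=O)/C(=N\OC(C)(C)C(=O)O)c2csc(N)n2)C(=O)N1S(=O)(=O)O)C(=O)CN` gives 212 h. Compound 2 `CC(C)(O/N=C(\C(=O)N[C@@H]1C(=O)N(S(=O)(=O)O)[C@@H]1CN1CCCC1=O)c1csc(N)n1)C(=O)O` gives > 1000 h, which is a limit of the assay and not a number. Compound 3 `CC(C)(O/N=C(\C(=O)N[C@@H]1C(=O)N(S(=O)(=O)O)[C@@H]1CN1CCNC1=O)c1csc(N)n1)C(=O)O` gives > 1000 h, again a limit and not a number.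

Compound 4 `CC(C)(O/N=C(\C(=O)N[C@@H]1C(=O)N(S(=O)(=O)O)[C@@H]1Cn1cnnc1)c1csc(N)n1)C(=O)O` is still unmeasured. It differs from compound 3 on a saturated chain carbon bound to a saturated ring carbon: 4H-1,2,4-triazol-4-yl in place of 2-oxoimidazolidin-1-yl on a saturated chain carbon bound to a saturated ring carbon.

Three measured steps changed this same place. Putting 2-oxopyrrolidin-1-yl in place of the open ((aminomethyl)carbonyl)(methyl)amino group gave an at least 4.7-fold higher number from compound 1 to compound 2 (0.67 log units; beyond the scatter). Putting 2-oxoimidazolidin-1-yl there gave an at least 4.7-fold higher number from compound 1 to compound 3 (0.67 log units; beyond the scatter). Between the two rings there is a step that the two limits leave unreadable from compound 2 to compound 3.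

None of these steps brings in an aromatic ring, so they are only a loose guide. Still, both readable steps came with a ring in place of the open group, and compound 4 also carries a ring at this place, so a long half-life is expected.

No change beyond the scatter is expected, and the estimated step is an at least 1.2-fold lower number from compound 3 to compound 4 (0.09 log units; that floor lies within the scatter).

For compound 4 the estimated half-life is 800 h, with an expected range from 250 h to 2000 h.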

Compound 4, half-life: 113 h
The estimate for compound 4 lay 7.1-fold (0.85 log units) above the measured number; measured number below the stated range.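

In this assay, a ring at this place is not enough to keep the half-life long: replacing 2-oxoimidazolidin-1-yl with 4H-1,2,4-triazol-4-yl gives an at least 8.8-fold lower number from compound 3 to compound 4 (0.94 log units; beyond the scatter), and replacing 2-oxopyrrolidin-1-yl with the same aromatic ring gives an at least 8.8-fold lower number from compound 2 to compound 4 (0.94 log units; beyond the scatter). Set against the open ((aminomethyl)carbonyl)(methyl)amino group, this ring gives a 1.9-fold lower number from compound 1 to compound 4 (0.27 log units; within the scatter), so compound 4 goes against the pattern seen in compound 2 and compound 3, where a ring in place of the open group came with a longer half-life. The true size of the two steps from the non-aromatic rings cannot be read, and only their floors are known: the limit of > 1000 h in this assay, at which 2 of the 4 values shown sit.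

On these data alone, the step between compound 2 and compound 3 cannot be read, so the order of these two rings stays open. The compounds shown also cannot separate the effect of aromaticity from the loss of the ring carbonyl, a question that a plain pyrrolidin-1-yl ring or an imidazol-1-yl ring at this place would bear on.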